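A Fluoro Substitution Tested in the Rice Read-out

This account rests on a few compounds, and the source may have more. Where it says the series, first, only, none or still open, it means among the compounds named here.

For the measured compounds named here, compound 2 `CCOC(=O)c1cccc(NC(=O)N[C@@H](C)c2ccccc2)c1` gives 96% in an ADME assay on the whole organism with Oryza sativa as the target, tested at 10 uM (on this read-out lower numbers stand for a stronger effect and higher numbers for a weaker effect at the one concentration tested), the highest of the two numbers known so far. Compound 1 `CCOC(=O)c1cccc(NC(=O)N[C@H](C)c2ccccc2)c1` gives 88% in this assay, and the step of a number 8 percentage points higher from compound 1 to compound 2 (within the scatter) lies within the scatter, arising from the fact that compounds 1 and 2 differ only in the configuration as drawn. Compound 3 `C[C@H](NC(=O)Nc1cccc(F)c1)c1ccccc1` differs from compound 2 by fluoro in place of ethoxycarbonyl on an aromatic carbon. Going by the values given here, no measured step touches this exchange; the single step known concerns configuration alone and was small, so a change beyond the scatter in this assay is not expected. Compound 3 is therefore estimated at 85%, between 55% and 110%, an expected step of a number 11 percentage points lower from compound 2 to compound 3 (beyond the scatter).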

Compound 3, a percentage reported as activity, at one concentration (the size of the read-out at that concentration, not a potency): 88%
Compound 3: middle estimate off by 3 percentage points, on the low side, within the range that was stated.
By their numbers in this assay, from the lowest: compounds 1, 3 and 2 (each within the scatter of the next).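

In this assay, replacing ethoxycarbonyl with fluoro on an aromatic carbon, meta to a large group, gives a number 8 percentage points lower from compound 2 to compound 3 (within the scatter), so the two groups cannot be told apart at this position. For the compounds shown here, the earlier pair spoke only to configuration at the chain carbon, whereas this step is the first reading of a change on the aromatic ring. Nothing available accounts for this step. From the compounds shown here alone, whether an amine or a carboxylic acid at the same place would also read alike remains open. So does the effect of fluoro combined with the opposite configuration.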